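This account rests on a few compounds, and the source may have more. Where it says the series, first, only, none or still open, it means among the compounds named here.

Series notes. The shared core carries a varied amine on the saturated chain carbon bound to an aromatic carbon. Compound 1 `CC1CCCN(Cc2c(-c3nnc(SC(C)C)n3-c3ccccc3)n(C)c3ccc(F)cc23)C1` gives 6.18 in a physicochemical assay for lipophilicity; on this read-out lower numbers stand for lower lipophilicity and higher numbers for higher lipophilicity. Compound 2 `COc1ccc(CNCc2c(-c3nnc(SC(C)C)n3-c3ccccc3)n(C)c3ccc(F)cc23)cc1` gives 6.42 in this assay, and compound 3 `COCCNCc1c(-c2nnc(SC(C)C)n2-c2ccccc2)n(C)c2ccc(F)cc12` gives 4.52. Compound 2 stands highest of the three numbers: its nearest neighbour is compound 1, a number 0.24 log units higher from compound 1 to compound 2 (within the scatter), and its furthest is compound 3, a number 1.90 log units lower from compound 2 to compound 3 (beyond the scatter). The remaining step, a number 1.66 log units lower from compound 1 to compound 3 (beyond the scatter), also concerns the amine.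

Compound 4 `COc1ccc(CNCc2c(-c3nnc(SC(C)C)n3-c3ccccc3)n(C)c3ccccc23)cc1` differs from compound 2 elsewhere: hydrogen in place of fluoro on an aromatic carbon. Fluoro leaves and hydrogen enters on an aromatic carbon of a six-membered aromatic ring of carbon only, part of a fused system of two rings. None of the three measured steps touches this position, since all three exchange the amine substituent, and the two large ones, a number 1.66 log units lower from compound 1 to compound 3 (beyond the scatter) and a number 1.90 log units lower from compound 2 to compound 3 (beyond the scatter), involve compound 3. Going by the values given here, no measured step bears directly on this change. In this assay the step is expected to be a number 0.17 log units lower from compound 2 to compound 4 (within the scatter), not beyond the scatter. For compound 4 the expected value is 6.25, with a range from 5.85 to 6.65.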

Compound 4, partition coefficient: 6.27
For compound 4 the middle estimate is 0.02 log units below the measured one, within the range that was stated.
By their numbers in this assay, from the lowest: compound 3; then compounds 1, 4 and 2 (each within the scatter of the next).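

In this assay, the exchange of fluoro for hydrogen on this aromatic carbon of the fused system gives a number 0.15 log units lower from compound 2 to compound 4 (within the scatter), so with (4-methoxybenzyl)amino held in place the two compounds cannot be told apart on this read-out. Going by these compounds alone, this is the only reading at this position, as every earlier step exchanged the amine on the chain carbon, and it rests on a single pair. Nothing at hand offers an explanation for this result.

As far as these compounds go, whether the same holds with 3-methylpiperidin-1-yl or (2-methoxyethyl)amino on the chain carbon stays open: compound 1 and compound 3 both carry fluoro, and neither has a hydrogen partner here. Also open, from the compounds shown here alone, is how chloro, methoxy or a nitrile on this aromatic carbon would read in this assay.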